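A few compounds are considered here, and "the series" means these few. Any claim that something is new, unique, unknown or untested is made for them only; others in the source may bear on it.

Compound 1 `COc1cc(C(C2=C(O)C(=O)c3ccccc3C2=O)c2c[nH]c3ccc(Br)cc23)cc(OC)c1OC` carries a 3,4,5-trimethoxyphenyl group on the saturated chain carbon of its shared core. In a functional assay on ECa-109 cells (Homo sapiens) for cytotoxicity, read by MTT assay, with a stated time of 48 h (a lower number here means a stronger inhibitor, a higher number a weaker inhibitor), compound 1 gives 13000 nM. Within the data shown here, the only other measured compound, compound 2 `COc1ccc(C(C2=C(O)C(=O)c3ccccc3C2=O)c2c[nH]c3ccccc23)cc1Br`, differs in more than one place, and in this assay compound 2 gives 11800 nM; the two numbers lie within the usual scatter of each other, so neither can be called the stronger inhibitor.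

Compound 3 `O=C1C(O)=C(C(c2ccc([N+](=O)[O-])cc2)c2c[nH]c3ccc(Br)cc23)C(=O)c2ccccc21` is not yet measured. The change from compound 1 is 4-nitrophenyl in place of 3,4,5-trimethoxyphenyl on a saturated chain carbon bound to an aromatic carbon and a double-bonded ring carbon. Among the measured compounds shown here, no pair of measured compounds shows this change on its own, so the numbers give no guide to its size or direction. With both measured compounds lying close together, the expected step in this assay from compound 1 to compound 3 is a 1.2-fold lower number from compound 1 to compound 3 (0.07 log units; within the scatter), which is no move beyond the scatter. Compound 3 is therefore estimated at 11000 nM, within a range of 3500 nM to 35000 nM.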

Compound 3, half-maximal inhibitory concentration: 16900 nM
Compound 3: middle estimate off by 1.5-fold (0.19 log units), on the low side; low and high end bracket the measured number.
By their numbers in this assay, from the lowest: compounds 2, 1 and 3 (each within the scatter of the next).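

In this assay, among these compounds, there is now a first change that can be read alone: 4-nitrophenyl in place of 3,4,5-trimethoxyphenyl on a saturated chain carbon bound to an aromatic carbon and a double-bonded ring carbon gives a 1.3-fold higher number from compound 1 to compound 3 (0.11 log units; within the scatter) and so cannot be told apart from repeat-measurement noise. At this position, then, two quite differently substituted phenyl groups give numbers that cannot be separated, although this single pair says nothing about other groups there. No separate measurement bears on why these two groups give such similar numbers.

All three compounds shown carry a substituted phenyl ring at this position, so it remains open whether the ring itself is needed. A carboxylic acid, an amine or a longer alkyl chain in place of that ring could move the number well beyond the scatter or leave it unchanged.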